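Methyl to fluoro at the edge of a cytotoxicity limit

A few compounds are considered here, and "the series" means these few. Any claim that something is new, unique, unknown or untested is made for them only; others in the source may bear on it.

In an ADME assay on BJ cells (Homo sapiens) for cytotoxicity, with a stated time of 72 h (on this read-out lower numbers stand for an effect already at smaller amounts and higher numbers for an effect only at larger amounts of compound), compound 1 `Cc1cc(NC(=O)Nc2ccc(C(C)(C)C)cc2)c2ccccc2n1` gives 20000 nM. Compound 2 `CCc1ccc(NC(=O)Nc2cc(C)nc3ccccc23)cc1` gives only a limit, > 25000 nM. Compound 3 `Cc1ccc(NC(=O)Nc2cc(C)nc3ccccc23)cc1` also gives only a limit, > 25000 nM. Compound 3 thus stands at the limit of > 25000 nM in this assay, at which 2 of the 3 values shown sit.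

Compound 4 `Cc1cc(NC(=O)Nc2ccc(F)cc2)c2ccccc2n1` differs from compound 3 by fluoro in place of methyl on an aromatic carbon, para to a large group. The closest measured changes fall on that same carbon. Methyl in place of tert-butyl gave an at least 1.2-fold higher number from compound 1 to compound 3 (0.09 log units; that floor lies within the scatter), and ethyl in place of tert-butyl gave an at least 1.2-fold higher number from compound 1 to compound 2 (0.09 log units; that floor lies within the scatter). Hydrogen in place of methyl on the chain gave a step that the two limits leave unreadable from compound 2 to compound 3. None of these shows a step beyond the scatter.

The expected change is a number no higher from compound 3 to compound 4 (the limit leaves the size open), and no step beyond the scatter is expected. For compound 4 the estimate is 25000 nM, with an expected range from 13000 nM to 50000 nM.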

Compound 4, half-maximal effective concentration: > 25000 nM
Compound 4 was reported as a limit; the forecaster's own chance of this, stated with the estimate: 75%; the middle value lies on the limit itself.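

Fluoro, the first group here on this carbon that is not built from carbon, ends at the same limit as methyl and ethyl, and compound 4 reports only that limit: the limit of > 25000 nM in this assay, at which 3 of the 4 values shown sit. Fluoro in place of tert-butyl gives an at least 1.2-fold higher number from compound 1 to compound 4 (0.09 log units; that floor lies within the scatter). The steps to compound 4 from compound 2 and from compound 3 cannot be read, as both ends of each are limits.

From the compounds shown here alone, the true numbers of compound 2, compound 3 and compound 4 stay open. So does whether an amine, a carboxylic acid or a longer chain on this carbon would give a readable number.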